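Removing the fluoro: from compound 3 to compound 4

The source may hold more compounds than are shown below. What is called first, only, known or untested is meant among the compounds shown, and "the series" means these compounds.

Measured so far in a functional assay on A549 cells (Homo sapiens) for cytotoxicity, read by MTT assay, with a stated time of 48 h; on this read-out higher numbers stand for weaker inhibition and lower numbers for stronger inhibition:
compound 1 `COc1cc(COCc2cn(Cc3cc(-c4ccccc4)cnc3Cl)nn2)cc(OC)c1OC` gives 62600 nM
compound 2 `COc1cc(COCc2cn(Cc3cc(-c4ccc(F)cc4)cnc3Cl)nn2)cc(OC)c1OC` gives 50600 nM
compound 3 `COc1cc(-c2cc(COCc3cn(Cc4cc(-c5ccc(F)cc5)cnc4Cl)nn3)on2)cc(OC)c1OC` gives 40600 nM

Compound 3 carries the lowest of the three numbers as read in this assay, but its gap to compound 2 and its gap to compound 1 both sit within the scatter, so no real order among the three can be drawn from these values.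

Compound 4 is `COc1cc(-c2cc(COCc3cn(Cc4cc(-c5ccccc5)cnc4Cl)nn3)on2)cc(OC)c1OC`. It differs from compound 3 by hydrogen in place of fluoro on an aromatic carbon.

Among the compounds with values here, one measured step bears on this change, namely the same exchange run the other way: a 1.2-fold lower number from compound 1 to compound 2 (0.09 log units; within the scatter). That step did not rise beyond the scatter. Within the data shown here, nothing else in the set addresses the 4-fluorophenyl to phenyl exchange, and the two measured pairs share everything but that group, so the reverse step is the only guide. The expectation is therefore a step of about the same size in the opposite direction, toward a somewhat higher number yet still inside the scatter; the expected step is a 1.2-fold higher number from compound 3 to compound 4 (0.07 log units; within the scatter). Compound 4 is accordingly estimated at 48000 nM, with a range from 26000 nM to 90000 nM.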

Compound 4, half-maximal inhibitory concentration: 112000 nM
Compound 4: the middle estimate sits 2.3-fold (0.37 log units) below what was measured; the measured number lies above the stated range.
By their numbers in this assay, from the lowest: compounds 3, 2, 1 and 4 (each within the scatter of the next, the first and the last beyond it).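

In this assay, within the data shown here, the 4-fluorophenyl to phenyl change gives a 2.8-fold higher number from compound 3 to compound 4 (0.44 log units; beyond the scatter), the first step at this position to pass beyond the scatter, though it is modest in size. The fluoro therefore has a readable effect on the core of compound 3, whereas the same exchange on the core of compound 1 stayed within the scatter. Even so, the two steps cannot be told apart, so the core cannot be said to alter what this change does: the same change on two cores in this assay, a 1.2-fold lower number (0.09 log units; within the scatter) from compound 1 to compound 2 and a 2.8-fold lower number (0.44 log units; beyond the scatter) from compound 4 to compound 3, 2.2-fold (0.35 log units) apart, within the scatter of two such steps.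

The compounds shown compare only fluoro and hydrogen at this place, on an aromatic carbon para to a large group, so it remains open whether the step is particular to fluoro or would also appear with a chloro, a nitrile or an amine there. Also open, going by these compounds, is whether a step of this size would recur on a further core, as two pairs cannot settle how far the result on the core of compound 3 extends.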